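Adding methoxy to the 4-hydroxyphenyl end of the series

A few compounds are considered here, and "the series" means these few. Any claim that something is new, unique, unknown or untested is made for them only; others in the source may bear on it.

Of the compounds shown here, two have numbers so far. In a functional assay on SK-N-SH cells (Homo sapiens) for cytotoxicity, read by MTT assay, with a stated time of 24 h (a higher number here means a weaker inhibitor, a lower number a stronger inhibitor), compound 1 (`C/C(=N\NC(=O)/C(C#N)=C/c1ccccc1)c1c(O)c2ccc(O)cc2oc1=O`) gives 13500 nM and compound 2 (`C/C(=N\NC(=O)/C(C#N)=C/c1ccc(O)cc1)c1c(O)c2ccc(O)cc2oc1=O`) gives 8120 nM, so compound 2 stands within the scatter of compound 1.

The next structure is compound 3 (`COc1cc(/C=C(\C#N)C(=O)N/N=C(\C)c2c(O)c3ccc(O)cc3oc2=O)ccc1O`). The change is methoxy in place of hydrogen on an aromatic carbon, ortho to a hydroxy group and meta to a large group, turning 4-hydroxyphenyl into 4-hydroxy-3-methoxyphenyl.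

Among the compounds with values here, the one measured step that bears on this is hydroxy in place of hydrogen on an aromatic carbon, with a 1.7-fold lower number from compound 1 to compound 2 (0.22 log units; within the scatter). Within the data shown here, it is a different substituent, and no measured compound carries the methoxy group, so the guidance is thin. With that single step as the guide, no change beyond the scatter is expected in this assay, in either direction, from the level of compound 2 at 8120 nM.

The expected step is a 1.1-fold lower number from compound 2 to compound 3 (0.03 log units; within the scatter). Compound 3 is estimated at 7500 nM, with an expected range of 3000 nM to 18000 nM.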

Compound 3, half-maximal inhibitory concentration: 14400 nM
Compound 3: middle estimate off by 1.9-fold (0.28 log units), on the low side; measured number inside the range.
By their numbers in this assay, from the lowest: compounds 2, 1 and 3 (each within the scatter of the next).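

In this assay, methoxy on the aromatic carbon ortho to the hydroxy group and meta to a large group, which turns 4-hydroxyphenyl into 4-hydroxy-3-methoxyphenyl, gives a 1.8-fold higher number from compound 2 to compound 3 (0.25 log units; within the scatter), so this position accepts a group of 2 heavy atoms with no step beyond the scatter. Read against the plain phenyl end, the full 4-hydroxy-3-methoxyphenyl group gives a 1.1-fold higher number from compound 1 to compound 3 (0.03 log units; within the scatter), so neither the single hydroxy step nor the further methoxy step, nor the two together, separates these aryl ends in this assay. No measurement at hand bears on the reason for these numbers.

The compounds shown leave open whether any group at this aromatic carbon can produce a step beyond the scatter, since the three numbers give no trend to follow and a larger ethoxy group, an amine or a carboxylic acid there would test it. They also leave open whether methoxy gives the same reading without the hydroxy group on the ring, as a 3-methoxyphenyl end would show.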